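Swapping One Triazole for Another on a Shared Core

A few compounds are considered here, and "the series" means these few. Any claim that something is new, unique, unknown or untested is made for them only; others in the source may bear on it.

compound 1 `CCC(C)(C)Cc1c[nH]c(CCc2ccc(-c3ccncc3)cc2)n1` — 103 nM
compound 2 `CCC(C)(C)Cc1c[nH]c(CCc2ccc(-n3ccnn3)cc2)n1` — 111 nM
compound 3 `c1ccc(-c2ccc(CCc3nc(CC4CCCC4)c[nH]3)cc2)nc1` — 103 nM

All three measured compounds were tested in a functional assay on HEK293 cells for agonist activity at Bombesin receptor subtype-3 (Mus musculus), read by luminescence and calcium flux, with a stated time of 10 min; on this read-out lower numbers stand for an effect already at smaller amounts and higher numbers for an effect only at larger amounts of compound. Compound 2 stands at the highest of the three numbers, yet its gap to compound 1 and its gap to compound 3 both lie within the scatter, so no order among the three can be read from these values; compound 2 sits level with the others.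

The unmeasured compound 4 `CCC(C)(C)Cc1c[nH]c(CCc2ccc(-n3cncn3)cc2)n1` differs from compound 2 in one place only: 1H-1,2,4-triazol-1-yl in place of 1H-1,2,3-triazol-1-yl on an aromatic carbon. Going by the values given here, only one measured step bears on this position, a 1.1-fold higher number from compound 1 to compound 2 (0.03 log units; within the scatter), which replaced one nitrogen-containing aromatic ring with another on the same aromatic carbon and left the number essentially unchanged. Among the compounds with values here, no measured pair compares the two triazole isomers with each other, so the expectation rests on that single step alone.

From this, the change from compound 2 to compound 4 is expected to give no step beyond the scatter, with a 1.1-fold higher number from compound 2 to compound 4 (0.03 log units; within the scatter) as the estimated shift. Compound 4 is therefore estimated at 120 nM in this assay, within a range from 50 nM to 300 nM.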

Compound 4, half-maximal effective concentration: 121 nM
Beside the measured number, compound 4's estimate is 1.0-fold (0.00 log units) below it, and the stated range covers the measured number.
By their numbers in this assay, from the lowest: compounds 1, 3, 2 and 4 (each within the scatter of the next).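

In this assay the two triazoles can now be compared directly: they have the same atoms joined differently, and putting 1H-1,2,4-triazol-1-yl in place of 1H-1,2,3-triazol-1-yl gives a 1.1-fold higher number from compound 2 to compound 4 (0.04 log units; within the scatter). The same new group in place of pyridin-4-yl gives a 1.2-fold higher number from compound 1 to compound 4 (0.07 log units; within the scatter), so on this aromatic carbon, para to a large group, the three rings of compounds 1, 2 and 4 sit level, and the arrangement of the nitrogens within the triazole does not show up in this read-out. Nothing available here offers a reason for this flat result.

On these data alone, all three groups compared at this position are aromatic rings that contain nitrogen, so it remains open whether the number would also stay level with a plain phenyl ring, an amine, a carboxylic acid or a longer chain on the same carbon. As far as these compounds go, it is also open whether either triazole would behave the same way alongside the different side chain of compound 3, which differs from these compounds in more than one place.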